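Dimethylsulfamoyl in place of propanoyl on compound 3

The source may report more compounds than this note shows. Statements on the series, on what has been measured and on what is new or still open speak of the compounds shown alone.

Measured in an ADME assay on HEK293-A cells (Homo sapiens) for cytotoxicity, read by MTT assay, with a stated time of 48 h; a lower number here means a stronger inhibitor, a higher number a weaker inhibitor:
compound 1 `O=C1O[C@@H](CO)CN1c1ccc(-n2cc(-c3ccccn3)cn2)c(F)c1` gives > 400 ug/mL (a limit of the assay, not a number)
compound 2 `O=C1O[C@@H](Cn2ccnn2)CN1c1ccc(-n2cc(-c3ccccn3)cn2)c(F)c1` gives 225 ug/mL
compound 3 `CCC(=O)NC[C@H]1CN(c2ccc(-n3cc(-c4ccccn4)cn3)c(F)c2)C(=O)O1` gives 389 ug/mL

Of the two true numbers, compound 2 at 225 ug/mL and compound 3 at 389 ug/mL lie within the scatter of each other, so compound 3 has no clear standing apart from compound 2. Compound 4 `CN(C)S(=O)(=O)NC[C@H]1CN(c2ccc(-n3cc(-c4ccccn4)cn3)c(F)c2)C(=O)O1` carries dimethylsulfamoyl in place of propanoyl on the amine nitrogen of compound 3: dimethylsulfamoyl in place of propanoyl on an amine nitrogen. Within the data shown here, no measured step covers this exact change. The nearest evidence is the set of changes on the same side chain: an at least 1.0-fold lower number from compound 1 to compound 3 (0.01 log units; that floor lies within the scatter), an at least 1.7-fold lower number from compound 1 to compound 2 (0.24 log units; that floor lies within the scatter) and a 1.7-fold higher number from compound 2 to compound 3 (0.24 log units; within the scatter). All three lie within the scatter, though the first two rest on a limit. On that basis no shift beyond the scatter is expected in this assay, and the estimated step is a 1.3-fold lower number from compound 3 to compound 4 (0.11 log units; within the scatter). The estimate for compound 4 is 300 ug/mL, with an expected range from 150 ug/mL to 450 ug/mL.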

Compound 4, half-maximal inhibitory concentration: 249 ug/mL
For compound 4 the middle estimate is 1.2-fold (0.08 log units) above the measured one; the measured number falls inside the stated range.
By their numbers in this assay, from the lowest: compounds 2, 4 and 3 (each within the scatter of the next). At a limit, above all of these: compound 1.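

In this assay, the amine nitrogen of the side chain accepts dimethylsulfamoyl in place of propanoyl with no shift beyond the scatter (a 1.6-fold lower number from compound 3 to compound 4 (0.19 log units; within the scatter)). The (dimethylsulfamoyl)amino group also stays within the scatter of 1H-1,2,3-triazol-1-yl (a 1.1-fold higher number from compound 2 to compound 4 (0.04 log units; within the scatter)), so compounds 2, 3 and 4 cannot be separated at this position. Compound 1 carries a limit of the assay rather than a number, so the comparison with hydroxy gives only a floor (an at least 1.6-fold lower number from compound 1 to compound 4 (0.20 log units; that floor lies within the scatter)), and the limit reads: the limit of > 400 ug/mL in this assay, at which 1 of the 4 values shown sits.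

From the compounds shown here alone, whether hydroxy truly differs from the other three groups remains open, since that floor lies within the scatter. Also open, going by these compounds, is whether a free amine, a carboxylic acid or a longer chain on this saturated chain carbon would give a step beyond the scatter.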